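Propylsulfanyl to benzylsulfanyl at the diphosphate: expected step

The compounds below may be only part of what the source reports. "The series", "measured", "known", "first", "only" and "open" are said of these compounds alone.

Compound 1 `CSc1nc(=O)ccn1[C@@H]1O[C@H](COP(=O)(O)OP(=O)(O)O)[C@@H](O)[C@H]1O` gives 4700 nM in an in vitro functional assay on 1321-N1 cells for agonist activity at P2Y purinoceptor 6 (Homo sapiens), read by scintillation proximity assay and inositol phosphate accumulation; on this read-out lower numbers stand for an effect already at smaller amounts and higher numbers for an effect only at larger amounts of compound. Compound 3 `CCCSc1nc(=O)ccn1[C@@H]1O[C@H](COP(=O)(O)OP(=O)(O)O)[C@@H](O)[C@H]1O`, with ethyl in place of hydrogen on the saturated chain carbon bound to a sulfur, reaches only a limit of this assay, >= 100000 nM; this is the limit of >= 100000 nM in this assay, at which 1 of the 3 values shown sits, so no number is known for compound 3, and it stands among the values that sit at a limit. The step of an at least 21-fold higher number from compound 1 to compound 3 (1.32 log units; beyond the scatter) is large and runs toward an effect only at larger amounts. Compound 2 `O=c1ccn([C@@H]2O[C@H](COP(=O)(O)O)[C@@H](O)[C@H]2O)c(SCCc2ccccc2)n1` likewise reaches only a limit in this assay, > 100000 nM; this is the limit of > 100000 nM in this assay, at which 1 of the 3 values shown sits.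

Compound 4 `O=c1ccn([C@@H]2O[C@H](COP(=O)(O)OP(=O)(O)O)[C@@H](O)[C@H]2O)c(SCc2ccccc2)n1` is not yet measured. It differs from compound 3 by phenyl in place of ethyl on a saturated chain carbon bound to a sulfur. Among the measured compounds shown here, the single measured step that bears on this change is an at least 21-fold higher number from compound 1 to compound 3 (1.32 log units; beyond the scatter), in which growing the chain on the sulfur from hydrogen to ethyl already carried the value to the limit. The further growth from ethyl to phenyl is expected to leave compound 4 at or past that limit, so the expected step of a number no higher from compound 3 to compound 4 (the limit leaves the size open) is none beyond the scatter. For compound 4 the estimate in this assay is 100000 nM, within 20000 nM to 500000 nM, with a high chance that only a limit is reported.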

Compound 4, half-maximal effective concentration: 6800 nM
Estimate against measurement, compound 4: 15-fold (1.17 log units) above; measured number outside the range, below it.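

In this assay, phenyl in place of ethyl on the saturated chain carbon bound to a sulfur gives an at least 14-fold lower number from compound 3 to compound 4 (1.16 log units; beyond the scatter), so growth of the group on this carbon does not carry the value only one way, and compound 4 goes against the trend suggested by the earlier step. Phenyl in place of hydrogen at the same carbon gives a 1.4-fold higher number from compound 1 to compound 4 (0.16 log units; within the scatter), which lies within the scatter, so among the diphosphates compound 1 and compound 4 cannot be told apart, while compound 3 stands apart from both. Compound 3 is only a limit, so the full size of its steps stays open: the limit of >= 100000 nM in this assay, at which 1 of the 4 values shown sits.

The series does not show whether the return to a measurable value depends on the aromatic ring itself or would also hold for cyclohexyl at this carbon, and the effect of a chloro or methoxy group on the phenyl ring is open as well. From the compounds shown here alone, compound 2 differs from compound 4 in more than one place, so the effect of a longer chain ending in phenyl at the diphosphate also stays open.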